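The source may report more compounds than this note shows. Statements on the series, on what has been measured and on what is new or still open speak of the compounds shown alone.

In a functional assay on MCF7 cells (Homo sapiens) for inhibition, read by trypan blue exclusion, with a stated time of 72 h (a lower number here means a stronger inhibitor of growth, a higher number a weaker inhibitor of growth), compound 3 (`CC/C(=C(\c1ccc(NC(=O)C(C)C)cc1)c1ccc(OC)cc1)c1ccc(O)cc1`) gives 9000 nM and sits within the scatter of compound 1 (`CC/C(=C(/c1ccc(NC(=O)C(C)C)cc1)c1ccc(OC)cc1)c1ccc(Cl)cc1Cl`) at 6600 nM as measured. Compound 2 (`CC/C(=C(\c1ccc(NC(=O)C(C)C)cc1)c1ccc(OC)cc1)c1ccccc1`) gives 27900 nM and stands beyond the scatter from compound 3. Compound 4 (`CC/C(=C(\c1ccc(NC(=O)C(C)C)cc1)c1ccc(OC)cc1)c1ccc(Cl)cc1Cl`) differs from compound 3 in carrying 2,4-dichlorophenyl in place of 4-hydroxyphenyl on a double-bonded chain carbon (2,4-dichlorophenyl in place of 4-hydroxyphenyl on a double-bonded chain carbon bound to a double-bonded chain carbon and a saturated chain carbon) of the shared core. Among the compounds with values here, the one measured step, a 3.1-fold lower number from compound 2 to compound 3 (0.49 log units; beyond the scatter) on gaining the hydroxy, is modest and hints that losing it could raise the number. Yet compound 1, which also bears 2,4-dichlorophenyl, gives 6600 nM and shows no such rise. No step beyond the scatter is therefore expected in this assay for this change. The expected step is a 1.1-fold lower number from compound 3 to compound 4 (0.05 log units; within the scatter) by this estimate. For compound 4 the estimate is 8000 nM with 3000 nM to 20000 nM as the expected range.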

Compound 4, concentration for 50% growth inhibition: 13200 nM
Beside the measured number, compound 4's estimate is 1.7-fold (0.22 log units) below it; the range from low to high includes it.
By their numbers in this assay, from the lowest: compounds 1, 3 and 4 (each within the scatter of the next); then compound 2.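

In this assay, 2,4-dichlorophenyl in place of 4-hydroxyphenyl gives a 1.5-fold higher number from compound 3 to compound 4 (0.17 log units; within the scatter), so at this double-bonded chain carbon the hydroxy is not required to stay at this level. Against plain phenyl, the same group gives a 2.1-fold lower number from compound 2 to compound 4 (0.33 log units; beyond the scatter), a modest step. Within the data shown here, the drawn double-bond geometry also stays within the scatter, with a 2.0-fold higher number from compound 1 to compound 4 (0.30 log units; within the scatter) as the only such reading: the fact that compounds 1 and 4 differ only in the configuration as drawn.

Going by these compounds, whether an amine or a carboxylic acid on this ring would keep the number at this level stays open. So does the effect of a longer chain on the saturated chain carbon.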